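This account rests on a few compounds, and the source may have more. Where it says the series, first, only, none or still open, it means among the compounds named here.

Measured compounds:
Compound 1, `Sc1ccnc(S)n1`, gives > 100000 nM in a functional assay on MCF7 cells (Homo sapiens) for cytotoxicity, read by MTT assay, with a stated time of 72 h; on this read-out lower numbers stand for stronger inhibition of growth and higher numbers for weaker inhibition of growth; this value is a limit of the assay, not a number.
Compound 2, `[SeH]c1ccnc([SeH])n1`, gives 40000 nM in this assay.
Compound 3, `CSc1ccc2ccccc2n1`, gives > 100000 nM in this assay; this value too is a limit of the assay, not a number.

Compound 3 therefore stands at the edge of what this assay can report: no growth inhibition was reached within the tested range, and it shares this position with one other entry, since (the limit of > 100000 nM in this assay, at which 2 of the 3 values shown sit). Of the three measured compounds only compound 2 yields a real number, and that number lies in the weak range of the assay.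

Compound 4, `C[Se]c1ccc2ccccc2n1`, has not yet been measured. It differs from compound 3 by a group of 2 heavy atoms (1 carbon, 1 selenium; no ring) in place of a group of 2 heavy atoms (1 carbon, 1 sulfur; no ring), on an aromatic carbon. Among the measured compounds shown here, no measured pair shows this exchange on its own, so the size of the step cannot be read from the data. The expectation is a modest move toward stronger inhibition, with a real possibility that compound 4 also stays at the limit. Compound 4 is estimated to give 70000 nM in this assay, within a range from 20000 nM to 200000 nM. The step this expectation implies is an at least 1.4-fold lower number from compound 3 to compound 4 (0.15 log units; that floor lies within the scatter).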

Compound 4, concentration for total growth inhibition: > 100000 nM
Compound 4 gave a limit, no number; the forecaster's own chance of this, stated with the estimate: 45%; middle value at least 1.4-fold (0.15 log units) away from the limit.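

In this assay compound 3 and compound 4 both end at a limit of the assay rather than a number, so no step can be read between them: the limit of > 100000 nM in this assay, at which 3 of the 4 values shown sit. The compounds shown leave open whether exchanging the methylsulfanyl group for its selenium counterpart on the shared core changes growth inhibition at all.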